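The source may report more compounds than this note shows. Statements on the series, on what has been measured and on what is new or still open speak of the compounds shown alone.

Measured so far in an assay on microsomes from brain for inhibition of Fatty-acid amide hydrolase 1 (Rattus norvegicus), read by fluorescence and HPLC, with a stated time of 60 min; a higher number here means a weaker inhibitor, a lower number a stronger inhibitor:

compound 1 `CCCCCCCCc1ccc(OCC(=O)Cn2nnc(-c3ccc(S(=O)(=O)N(C)C)cc3)n2)cc1` — 590 nM
compound 2 `CCCCCCCCc1ccc(OCC(=O)Cn2nnc(-c3cccnc3)n2)cc1` — 23 nM
compound 3 `CCCCCCCCc1ccc(OCC(=O)Cn2nnc(C(=O)O)n2)cc1` — 41 nM

Compound 3 gives the second highest of the three numbers. Its nearest neighbour is compound 2, and a 1.8-fold higher number from compound 2 to compound 3 (0.25 log units; within the scatter) falls within the scatter, so no order can be read between them. Compound 1 is the furthest off: a 14-fold lower number from compound 1 to compound 3 (1.16 log units; beyond the scatter), and likewise a 26-fold lower number from compound 1 to compound 2 (1.41 log units; beyond the scatter), both large steps that show the group carried on the shared core can move the number strongly.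

Compound 4 `CCCCCCCCc1ccc(OCC(=O)Cn2nnc(C(=O)OC)n2)cc1` is not yet measured. Going from compound 3 to compound 4 the change is methyl in place of hydrogen on an oxygen next to a carbonyl group: the carboxy becomes methoxycarbonyl. Within the data shown here, none of the measured steps covers this exchange; the two large steps concern whole aryl groups leaving, and the within-scatter step between compound 2 and compound 3 concerns a different pair. A direct precedent is lacking, so the direction is open. For compound 4 the step of a 1.2-fold higher number from compound 3 to compound 4 (0.09 log units; within the scatter) is expected to stay modest, within or near the scatter. The estimate for compound 4 in this assay is 50 nM, with a range from 10 nM to 250 nM.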

Compound 4, half-maximal inhibitory concentration: 88 nM
The estimate for compound 4 lay 1.8-fold (0.25 log units) below the measured number, within the range that was stated.
By their numbers in this assay, from the lowest: compounds 2 and 3 (each within the scatter of the next); then compound 4; then compound 1.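

In this assay, methyl in place of hydrogen on an oxygen next to a carbonyl group gives a step beyond the scatter (a 2.1-fold higher number from compound 3 to compound 4 (0.33 log units; beyond the scatter)), so this position responds to a change as small as one added carbon, which the whole-group exchanges measured earlier could not show. Methoxycarbonyl also stands apart from pyridin-3-yl (a 3.8-fold higher number from compound 2 to compound 4 (0.58 log units; beyond the scatter)), although no order could be read between carboxy and pyridin-3-yl, and it keeps most of the gain over 4-(dimethylsulfamoyl)phenyl (a 6.7-fold lower number from compound 1 to compound 4 (0.83 log units; beyond the scatter)). Nothing available accounts for the shift from hydrogen to methyl on this oxygen.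

From the compounds shown here alone, whether an ethyl ester would move the number further in the same direction remains open. So does whether a primary amide in place of the ester would stay with carboxy or with methoxycarbonyl.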